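The source may hold more compounds than are shown below. What is called first, only, known or untested is meant among the compounds shown, and "the series" means these compounds.

- compound 1 `COC(=O)c1ccc(CN(CCCc2c(N)nc(N)nc2O)c2cc(F)c([N+](=O)[O-])cc2[N+](=O)[O-])cc1`: 2500 nM
- compound 2 `Nc1nc(N)c(CCCNc2cc(F)c([N+](=O)[O-])cc2[N+](=O)[O-])c(O)n1`: 1000 nM

For the measured compounds named here, in a functional assay on CCRF-CEM cells (Homo sapiens) for cytotoxicity, in the absence of a further agent (a lower number here means a stronger inhibitor, a higher number a weaker inhibitor), compound 1 gives 2500 nM, the higher of the two numbers so far, which makes it the weaker inhibitor of the pair. The next molecule, compound 3 `COC(=O)c1ccc(CN(CCCc2c(N)nc(N)nc2O)c2cc(F)ccc2[N+](=O)[O-])cc1`, differs from compound 1 in one place: hydrogen in place of nitro on an aromatic carbon. This is hydrogen in place of nitro on an aromatic carbon, ortho to a fluoro group and meta to a nitro group.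

Going by the values given here, the only measured step is a 2.5-fold lower number from compound 1 to compound 2 (0.40 log units; beyond the scatter). It swaps 4-(methoxycarbonyl)benzyl for hydrogen on a nitrogen, so it says nothing direct about losing a nitro. It serves only as a rough guide to size, and the direction stays uncertain. A small move in this assay is expected, within the scatter, with a tentative lean towards a higher number. The expected step is a 1.6-fold higher number from compound 1 to compound 3 (0.20 log units; within the scatter). Compound 3 is estimated at 4000 nM, with an expected range of 1200 nM to 13000 nM.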

Compound 3, half-maximal inhibitory concentration: 45000 nM
For compound 3 the middle estimate is 11-fold (1.05 log units) below the measured one; measured number outside the range, above it.
By their numbers in this assay, from the lowest: compound 2; then compound 1; then compound 3.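

In this assay, replacing the nitro group with hydrogen at this position, ortho to a fluoro group and meta to a nitro group, gives an 18-fold higher number from compound 1 to compound 3 (1.26 log units; beyond the scatter) and so a much weaker inhibitor. This nitro group therefore matters far more to the cytotoxicity read-out than its modest predecessor step on the nitrogen suggested, and the second nitro group, still present in compound 3, does not make up for its loss. Nothing available here explains why the change is so large.

The compounds shown compare only nitro with hydrogen at this position, so it remains open whether a nitrile, an amine or a chlorine atom there would keep the activity of compound 1. On these data alone, it is also open whether the same loss would appear in compound 2, which carries hydrogen on the nitrogen.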